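A few compounds are considered here, and "the series" means these few. Any claim that something is new, unique, unknown or untested is made for them only; others in the source may bear on it.

Measured so far:
compound 1 `CC(C)(C)NC(=O)CCc1cccc2c1B(O)OC2`: > 100000 nM
compound 2 `O=C(CCc1cccc2c1B(O)OC2)NC1CCCCC1`: > 100000 nM
compound 3 `O=C(CCc1cccc2c1B(O)OC2)Nc1ccc(Br)cc1`: 46000 nM

All three compounds were tested in a functional assay on HCT-116 cells (Homo sapiens) for antiproliferative activity, read by MTT assay, with a stated time of 72 h; on this read-out lower numbers stand for stronger inhibition and higher numbers for weaker inhibition. For compound 1, the entry > 100000 nM is a limit and not a number. For compound 2, the entry > 100000 nM is likewise a limit. For the measured compounds named here, compound 3 gives 46000 nM, the only true number among the three.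

Putting 4-bromophenyl on the amide nitrogen in place of tert-butyl gives an at least 2.1-fold lower number from compound 1 to compound 3 (0.33 log units; beyond the scatter). Putting it there in place of cyclohexyl gives an at least 2.1-fold lower number from compound 2 to compound 3 (0.33 log units; beyond the scatter). Replacing tert-butyl with cyclohexyl gives a step that the two limits leave unreadable from compound 1 to compound 2.

Compound 4 `CC(C)(C)OC(=O)NCc1ccc(NC(=O)CCc2cccc3c2B(O)OC3)cc1` keeps the aromatic ring of compound 3 and changes the group on it: ((tert-butoxycarbonyl)amino)methyl in place of bromo on an aromatic carbon. Here ((tert-butoxycarbonyl)amino)methyl replaces bromo on an aromatic carbon, para to a large group. Going by the values given here, no measured step changes a group on this ring, so the steps to compound 3 bear on it only indirectly. Compound 4 keeps the 4-substituted phenyl type of amide, but the limit of > 100000 nM in this assay, at which 2 of the 3 values shown sit, shows how near the series lies to its ceiling.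

The expected change is small, within the scatter: a 1.2-fold lower number from compound 3 to compound 4 (0.06 log units; within the scatter). For compound 4 the estimated value is 40000 nM, with an expected range from 12000 nM to 100000 nM.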

Compound 4, half-maximal inhibitory concentration: 2300 nM
The estimate for compound 4 lay 17-fold (1.24 log units) above the measured number; measured number outside the range, below it.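

In this assay, the group on the aromatic ring turns out to matter a great deal: ((tert-butoxycarbonyl)amino)methyl in place of bromo gives a 20-fold lower number from compound 3 to compound 4 (1.30 log units; beyond the scatter). The earlier steps shown here changed only the group on the amide nitrogen, so they said nothing about this place on the ring, para to a large group. It now emerges that this place accepts a group of 9 heavy atoms in place of 1, and that the number falls sharply rather than rises, so the ring substituent is a strong lever in this series. Compound 1 and compound 2 remain limits and not numbers, which leaves compound 4 as the first reading in the series far from that ceiling: the limit of > 100000 nM in this assay, at which 2 of the 4 values shown sit.

The entering group brings a carbonyl, a nitrogen with its hydrogen and a tert-butyl end all at once, so this one step cannot say which part carries the change. Going by these compounds, a plain aminomethyl group or a carboxylic acid at the same place would help separate these parts, and it remains open whether a longer chain would lower the number further.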